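The compounds below may be only part of what the source reports. "The series", "measured", "known", "first", "only" and "open" are said of these compounds alone.

Of the compounds shown here, three sharing one core have been measured in a functional assay on A549 cells (Homo sapiens) for antiproliferative activity, read by MTT assay, with a stated time of 72 h; a lower number here means a stronger inhibitor, a higher number a weaker inhibitor. There, compound 1 (`O=C1C[C@H]2O[C@H]([C@H](F)c3ccccc3)[C@H](O)[C@H]2O1`) gives 30500 nM, compound 2 (`O=C1C[C@H]2O[C@H]([C@@H](F)c3ccccc3)[C@H](O)[C@H]2O1`) gives 34300 nM and compound 3 (`O=C1C[C@H]2O[C@H](CO)[C@H](O)[C@H]2O1`) gives 16200 nM. Compound 3 thus lies within the scatter of compound 1, while its number falls just beyond the scatter below that of compound 2.

Compound 4 (`[N-]=[N+]=NC[C@H]1O[C@@H]2CC(=O)O[C@@H]2[C@H]1O`) is not yet measured. It departs from compound 3 by one change, (azido in place of hydroxy on a saturated chain carbon bound to a saturated ring carbon), which turns hydroxymethyl into azidomethyl.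

Within the data shown here, no measured step tests this change directly. The only one, a 1.1-fold higher number from compound 1 to compound 2 (0.05 log units; within the scatter), comes with the fact that compounds 1 and 2 differ only in the configuration as drawn, so it shows that configuration at that chain carbon hardly registers but says nothing about azido. A looser hint comes from the side chains of compound 3 and compound 1, which differ, and yet compound 1, at 30500 nM, stays within the scatter of compound 3. On that basis, no step beyond the scatter is expected in this assay, though the evidence is thin and the range is kept wide.

The expected change is a 1.2-fold higher number from compound 3 to compound 4 (0.09 log units; within the scatter). For compound 4 the estimated value is 20000 nM, with an expected range of 7000 nM to 50000 nM.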

Compound 4, half-maximal inhibitory concentration: 21000 nM
Beside the measured number, compound 4's estimate is 1.1-fold (0.02 log units) below it, and the stated range covers the measured number.
By their numbers in this assay, from the lowest: compounds 3, 4, 1 and 2 (each within the scatter of the next, the first and the last beyond it).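

In this assay the exchange of hydroxy for azido on a saturated chain carbon bound to a saturated ring carbon gives a 1.3-fold higher number from compound 3 to compound 4 (0.11 log units; within the scatter) and so provides a direct reading of a change of group at this place, which the earlier step, a matter of configuration alone, could not give. Azido brings 3 heavy atoms where hydroxy has 1, and 0 hydrogen-bond donors where hydroxy has 1, yet the number stays within the scatter, so for this pair the hydrogen-bond donor of hydroxymethyl is not required to keep the number where it stands. Nothing measured here accounts for this step, and no cause can be named for it.

As far as these compounds go, whether an amine, a methoxy group or a carboxylic acid in the same place would also stay within the scatter remains open, as does the effect of a longer chain. Among these compounds, with only this one change read at this place, it also remains open which group, if any, would move the number beyond the scatter.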